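The compounds below may be only part of what the source reports. "The series", "measured", "known", "first", "only" and "open" are said of these compounds alone.

Measured compounds in a functional assay on KB cells (Homo sapiens) for inhibition; a lower number here means a stronger inhibitor of growth, a higher number a weaker inhibitor of growth:
- compound 2 `Cc1ccc(NC(=O)COc2ccc(/C=C3\SC(=O)NC3=O)cc2)cc1Cl` gives 99600 nM
- compound 1 `O=C(COc1ccc(/C=C2\SC(=O)NC2=O)cc1)Nc1ccc([N+](=O)[O-])cc1` gives > 100000 nM, which is a limit of the assay and not a number.

Compound 2 holds the only number shown in this assay; the one further value is a limit. The step from compound 1 to compound 2, a number no higher from compound 1 to compound 2 (the limit leaves the size open), rests on that limit (the limit of > 100000 nM in this assay, at which 1 of the 2 values shown sits), and its size is therefore not readable. Compound 3 `O=C(COc1ccc(/C=C2\SC(=O)NC2=O)cc1)Nc1c(Cl)cccc1Cl` differs from compound 2 by 2,6-dichlorophenyl in place of 3-chloro-4-methylphenyl on an amide-type nitrogen. Among the compounds with values here, the only step that bears on a change of the group on the amide-type nitrogen is the one from compound 1 to compound 2, and with its size open it fixes neither direction nor magnitude for compound 3. The step from compound 2 to compound 3 in this assay is expected to be a 1.0-fold higher number from compound 2 to compound 3 (0.00 log units; within the scatter). For compound 3 the estimate in this assay is 100000 nM, with a range from 30000 nM to 300000 nM, and a fair chance that only a limit is reported.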

Compound 3, concentration for 50% growth inhibition: > 100000 nM
Compound 3: no number, only a limit; the forecaster's own chance of this, stated with the estimate: 50%; the middle value lies on the limit itself.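

In this assay compound 3 gives > 100000 nM, which is a limit of the assay and not a number. Placing 2,6-dichlorophenyl on the amide-type nitrogen gives a number no lower from compound 2 to compound 3 (the limit leaves the size open), and neither the size of this step nor the step between the two limits, from the 4-nitrophenyl of compound 1 to the 2,6-dichlorophenyl of compound 3, can be read. A second group on this nitrogen now rests at the limit, so the change adds a boundary to the series and no measurable trend: the limit of > 100000 nM in this assay, at which 2 of the 3 values shown sit.

On these data alone, whether any group on this nitrogen can give a number clearly lower than that of compound 2 stays open. A benzyl group, a pyridyl group or a phenyl group carrying an amine or a carboxylic acid would test this.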